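Amide-linked acids on a shared polyhydroxy core

This account rests on a few compounds, and the source may have more. Where it says the series, first, only, none or still open, it means among the compounds named here.

The series shares the core of compound 1, `O=C(O)CCCNC(=O)[C@]1(O)C[C@@H](O)[C@@H](O)[C@H](O)C1`, carrying amide-linked acid chains. In an assay on HL-60 cells for inhibition of E-selectin (Homo sapiens) (a higher number here means a weaker inhibitor, a lower number a stronger inhibitor), compound 1 gives only the limit > 50000000 nM. Compound 2, `O=C(O)CCCCCNC(=O)[C@]1(O)C[C@@H](O)[C@@H](O)[C@H](O)C1`, gives in this assay only the limit > 50000000 nM. Compound 3, `O=C(O)CC[C@H](NC(=O)[C@]1(O)C[C@@H](O)[C@@H](O)[C@H](O)C1)C(=O)O`, gives in this assay only the limit > 50000000 nM. The two changes among the measured compounds, a step that the two limits leave unreadable from compound 1 to compound 2 and a step that the two limits leave unreadable from compound 1 to compound 3, are therefore not readable in size, and all that can be said is the limit of > 50000000 nM in this assay, at which 3 of the 3 values shown sit.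

Compound 4, `CCC(C)[C@H](NC(=O)[C@]1(O)C[C@@H](O)[C@@H](O)[C@H](O)C1)C(=O)O`, is the next member to be measured. The change from compound 3 is sec-butyl in place of 2-carboxyethyl on a saturated chain carbon bound to an amide-type nitrogen and a carbonyl carbon. Among the compounds with values here, no measured step is readable and so none bears directly on it; the only guide is that every value so far sits at the limit. The expectation is therefore a step of a number no higher from compound 3 to compound 4 (the limit leaves the size open) in this assay, which most likely means compound 4 also returns only a limit, and compound 4 is estimated at 50000000 nM with a range from 5000000 nM to 50000000 nM.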

Compound 4, half-maximal inhibitory concentration: > 50000000 nM
Compound 4 was reported as a limit; the forecaster's own chance of this, stated with the estimate: 85%; the middle value sits exactly at the limit.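

In this assay compound 4 gives > 50000000 nM as a limit and not a number, so the change from compound 3 to compound 4 cannot be read in size. The compounds shown leave open whether any change on the shared core gives a measurable inhibitor: the limit of > 50000000 nM in this assay, at which 4 of the 4 values shown sit.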